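Compound 3 to compound 4: a new aryl group

The source may hold more compounds than are shown below. What is called first, only, known or untested is meant among the compounds shown, and "the series" means these compounds.

In a functional assay on MDA-MB-231 cells (Homo sapiens) for cytotoxicity, read by MTT assay, with a stated time of 48 h (a lower number here means a stronger inhibitor, a higher number a weaker inhibitor), compound 1 `O=C(NCCCCC(c1ccc(F)cc1)c1ccc(F)cc1)Nc1cccc(C(F)(F)F)c1` gives 3380 nM, compound 2 `O=C(NCCCCC(c1ccc(F)cc1)c1ccc(F)cc1)Nc1cccc(Cl)c1` gives 5070 nM and compound 3 `O=C(NCCCCC(c1ccc(F)cc1)c1ccc(F)cc1)Nc1ccc([N+](=O)[O-])c(Cl)c1` gives 3470 nM. Compound 3 therefore stands within the scatter of both other compounds, with a 1.0-fold higher number from compound 1 to compound 3 (0.01 log units; within the scatter) and a 1.5-fold lower number from compound 2 to compound 3 (0.16 log units; within the scatter).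

Compound 4 `O=C(NCCCCC(c1ccc(F)cc1)c1ccc(F)cc1)Nc1ccc(Br)cc1I` carries 4-bromo-2-iodophenyl in place of 3-chloro-4-nitrophenyl on an amide-type nitrogen. The closest evidence comes from the measured changes on this aryl group, namely a 1.0-fold higher number from compound 1 to compound 3 (0.01 log units; within the scatter), a 1.5-fold higher number from compound 1 to compound 2 (0.18 log units; within the scatter) and a 1.5-fold lower number from compound 2 to compound 3 (0.16 log units; within the scatter). Among the measured compounds shown here, all three are small, but no measured compound carries bromo or iodo, so the data do not test the entering group directly. No step beyond the scatter is therefore expected in this assay, although the uncertainty is wider than these steps alone suggest. The estimated step is a 1.1-fold higher number from compound 3 to compound 4 (0.04 log units; within the scatter). For compound 4 the expected value is 3800 nM, with an estimated range of 1700 nM to 9000 nM.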

Compound 4, half-maximal inhibitory concentration: > 20000 nM
Compound 4 was reported as a limit; the forecaster's own chance of this, stated with the estimate: 3%; middle value at least 5.2-fold (0.72 log units) from the limit.
By their numbers in this assay, from the lowest: compounds 1, 3 and 2 (each within the scatter of the next). At a limit, above all of these: compound 4.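

In this assay, the aryl group on the amide-type nitrogen now matters: the earlier changes at this place all stayed within the scatter, whereas bringing in 4-bromo-2-iodophenyl gives an at least 5.7-fold higher number from compound 3 to compound 4 (0.76 log units; beyond the scatter), an at least 3.9-fold higher number from compound 2 to compound 4 (0.59 log units; beyond the scatter) and an at least 5.9-fold higher number from compound 1 to compound 4 (0.77 log units; beyond the scatter), each beyond the scatter. Compound 4 is reported as a limit, not a number: the limit of > 20000 nM in this assay, at which 1 of the 4 values shown sits. This place therefore accepts 3-(trifluoromethyl)phenyl, 3-chlorophenyl and 3-chloro-4-nitrophenyl with no difference beyond the scatter, but that tolerance does not extend to every aryl group.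

Bromo and iodo enter together in compound 4, so the compounds shown do not separate the contribution of either one, or of where each sits. Also open, on these data alone, is how an aryl group carrying bromo alone, iodo alone, an amine or a carboxylic acid would behave here.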